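The source may hold more compounds than are shown below. What is called first, only, known or untested is meant among the compounds shown, and "the series" means these compounds.

Measured compounds:
- compound 1 `Nc1ccccc1NC(=O)c1ccc(CSC(=S)N2CCN(Cc3ccncc3)CC2)cc1`: 59.5%
- compound 2 `Nc1ccccc1NC(=O)c1ccc(CSC(=S)N2CCN(Cc3cccnc3)CC2)cc1`: 69.7%

Among the compounds with values here, in a functional assay on HeLa cells (Homo sapiens) for antiproliferative activity, read by CCK-8 assay, with a stated time of 72 h, tested at 2 uM (a higher number here means a stronger effect of the compound at the concentration tested, a lower number a weaker effect), compound 2 holds the higher of the two numbers; its one neighbour, compound 1, sits lower by a number 10.2 percentage points higher from compound 1 to compound 2 (beyond the scatter), a modest step that rests on the swap of pyridin-3-yl for pyridin-4-yl on the saturated chain carbon bound to the ring amine nitrogen.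

Compound 3 `Nc1ccccc1NC(=O)c1ccc(CSC(=S)N2CCN(c3cnccn3)CC2)cc1` is the next member. Its difference from compound 2 is pyrazin-2-yl in place of (pyridin-3-yl)methyl on an amine nitrogen in a ring. Within the data shown here, no measured step covers this kind of change: the only step in hand, from compound 1 to compound 2, moves the ring nitrogen within an otherwise unchanged group, whereas here the (pyridin-3-yl)methyl group gives way to pyrazin-2-yl placed directly on the ring amine nitrogen. Among the measured compounds shown here, with a single modest step of unrelated kind as the only guide, the expected step of a number 7.7 percentage points lower from compound 2 to compound 3 (within the scatter) is none beyond the scatter. Compound 3 is therefore estimated at 62% in this assay, within 45% to 78%.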

Compound 3, a percentage reported as inhibition, at one concentration (the size of the read-out at that concentration, not a potency): 70.4%
Beside the measured number, compound 3's estimate is 8.4 percentage points below it; the range from low to high includes it.
By their numbers in this assay, from the lowest: compound 1; then compounds 2 and 3 (each within the scatter of the next).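

In this assay, the ring amine nitrogen accepts a group with no saturated chain carbon: with pyrazin-2-yl set directly on it, the change from (pyridin-3-yl)methyl gives a number 0.7 percentage points higher from compound 2 to compound 3 (within the scatter), so that carbon is not needed to keep the read-out of compound 2 in this pair. Within the data shown here, the same replacement set against (pyridin-4-yl)methyl gives a number 10.9 percentage points higher from compound 1 to compound 3 (beyond the scatter), leaving compound 1 as the only member apart from the others. Nothing measured here bears on why these groups give these numbers.

Open, as far as these compounds go, is whether a (pyrazin-2-yl)methyl group on the same nitrogen would match pyrazin-2-yl, which would separate the chain carbon from the second ring nitrogen. Also open, from the compounds shown here alone, is how a plain phenyl or an acetyl group on that nitrogen would read.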